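Cyclopropane carboxamide series: fluorine pattern on the aryl ring

This account rests on a few compounds, and the source may have more. Where it says the series, first, only, none or still open, it means among the compounds named here.

Measured so far:
compound 1 `CC(C)C[C@@H](N)CN(C(=O)[C@@H]1C[C@H]1c1ccccc1)c1ccc(-c2ccccc2)cc1`: 1.8 nM
compound 2 `CC[C@H](C)[C@H](N)CN(C(=O)[C@@H]1C[C@H]1c1ccc(F)cc1)c1ccc(-c2ccccc2)cc1`: 600 nM

In a functional assay for agonist activity at G protein-coupled receptor 88 (Homo sapiens), read by HTRF and cAMP accumulation (a higher number here means that more compound is needed for the effect, a lower number that less compound is needed), compound 1 gives 1.8 nM, and compound 2 gives 600 nM. Compound 2 thus holds the higher of the two numbers, and its gap to compound 1 lies well beyond the scatter of repeat measurements.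

Compound 3 `CC[C@H](C)[C@H](N)CN(C(=O)[C@@H]1C[C@H]1c1c(F)cccc1F)c1ccc(-c2ccccc2)cc1` is not yet measured. It differs from compound 2 as follows: 2,6-difluorophenyl in place of 4-fluorophenyl on a saturated ring carbon. For the measured compounds named here, no measured pair shows this change, so a step from compound 2 to compound 3 within the scatter is expected, in no settled direction, a 1.2-fold lower number from compound 2 to compound 3 (0.08 log units; within the scatter). Compound 3 is therefore estimated at 500 nM, with a range from 150 nM to 2000 nM.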

Compound 3, half-maximal effective concentration: 11000 nM
Compound 3: the middle estimate sits 22-fold (1.34 log units) below what was measured, and the stated range ends below it.
By their numbers in this assay, from the lowest: compound 1; then compound 2; then compound 3.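

In this assay, for the compounds shown here, 2,6-difluorophenyl in place of 4-fluorophenyl on a saturated ring carbon gives an 18-fold higher number from compound 2 to compound 3 (1.26 log units; beyond the scatter), the first single-place step. This aryl position is therefore sensitive to the fluorine pattern, and a second fluorine with a changed pattern does not leave the number within the scatter. Nothing at hand gives a cause for this step.

Open, as far as these compounds go, is whether the fluorine count or the pattern drives the step. Also open, from the compounds shown here alone, is how a methoxy or nitrile on this aryl ring would read.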